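Halogen swap on the benzylidene ring of the shared core

This account rests on a few compounds, and the source may have more. Where it says the series, first, only, none or still open, it means among the compounds named here.

Three members of the series have numbers in a functional assay on HEp-2 cells (Homo sapiens) for cytotoxicity, read by MTT assay, with a stated time of 72 h, tested at 10 ug/mL (on this read-out lower numbers stand for less inhibition of growth and higher numbers for more inhibition of growth at the one concentration tested), so far, and all of them share the core of compound 1 `O=C1NC(=S)/C(=C/c2ccc(Cl)cc2)S1`, which gives 22.3%. Compound 2 `O=C1NC(=S)/C(=C/c2ccccc2Br)S1` gives 21.2%, and compound 3 `O=C1NC(=S)/C(=C/c2cccc(Cl)c2)S1` gives 18.8%. The three numbers lie within the usual scatter of one another, so compound 2 cannot be set apart from compound 1 or compound 3 on this assay; its nearest neighbour by value is compound 1, and the gap to compound 3 is also inside the scatter. Within the data shown here, no pair among the measured compounds differs in a single place, so no measured step is available to lean on.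

Compound 4 `O=C1NC(=S)/C(=C/c2ccccc2F)S1` is not yet measured. Against compound 2 the change is fluoro in place of bromo on an aromatic carbon, in words fluoro in place of bromo on an aromatic carbon. Given that every measured compound sits in the same narrow band, the step expected from compound 2 to compound 4 in this assay, a number 2.2 percentage points lower from compound 2 to compound 4 (within the scatter), is small and not beyond the scatter in either direction. For compound 4 the estimated value in this assay is 19%, with a range from 8% to 30%.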

Compound 4, percent growth inhibition at one concentration: 11.2%
Compound 4: the middle estimate sits 7.8 percentage points above what was measured; the range from low to high includes it.
By their numbers in this assay, from the lowest: compounds 4, 3, 2 and 1 (each within the scatter of the next, the first and the last beyond it).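

Fluoro in place of bromo on an aromatic carbon, ortho to a group of 8 heavy atoms, is the first change in the series that can be read in one place: in this assay it gives a number 10 percentage points lower from compound 2 to compound 4 (within the scatter) for this exchange of one halogen for another. As that step stays inside the scatter, bromo and fluoro at this position cannot be told apart on this read-out, and compound 4 cannot be set apart from compound 2 by this single exchange. No measured property of either group bears on this step, and nothing in hand speaks to what lies behind the two numbers.

Open, as far as these compounds go, is whether a group of another kind on this same aromatic carbon, such as an amine, a methoxy group or a carboxylic acid, would give a step beyond the scatter from compound 2. Also open, from the compounds shown here alone, is whether fluoro in place of bromo reads the same on the other carbons of the six-membered ring, and whether any such change would hold at a concentration other than the one tested here.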